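One Chain Carbon Longer: What the Earlier Step Suggests

This account rests on a few compounds, and the source may have more. Where it says the series, first, only, none or still open, it means among the compounds named here.

Measured in a functional assay on NCI-H1299 cells (Homo sapiens) for inhibition, read by CCK-8 assay, with a stated time of 72 h, tested at 1 uM; on this read-out lower numbers stand for a weaker effect and higher numbers for a stronger effect at the one concentration tested:
compound 1 `CN(C)C(=O)c1cc2cnc(Nc3ccc(S(=O)(=O)NCCCCCCN=C=S)cc3)nc2n1C1CCCC1` gives 42.4%
compound 2 `CN(C)C(=O)c1cc2cnc(Nc3ccc(S(=O)(=O)NCCCCCCCN=C=S)cc3)nc2n1C1CCCC1` gives 58.9%
compound 3 `CN(C)C(=O)c1cc2cnc(Nc3ccc(C(=O)NCCCCN=C=S)cc3)nc2n1C1CCCC1` gives 55.2%

Compound 1 and compound 2 share a core and differ in one spot: a group of 4 heavy atoms (2 carbon, 1 nitrogen, 1 sulfur; no ring) in place of a group of 3 heavy atoms (1 carbon, 1 nitrogen, 1 sulfur; no ring), on a saturated chain carbon, six bonds along the chain from a sulfonamide nitrogen. That change produced a number 16.5 percentage points higher from compound 1 to compound 2 (beyond the scatter). Compound 3 carries a different linking group, and the difference between its core and the core of compound 1 is not broken down here. In this assay compound 3 and compound 2 lie within the usual scatter of each other.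

Compound 4 `CN(C)C(=O)c1cc2cnc(Nc3ccc(C(=O)NCCCCCN=C=S)cc3)nc2n1C1CCCC1` has not yet been measured. It differs from compound 3 by the same kind of change: a group of 4 heavy atoms (2 carbon, 1 nitrogen, 1 sulfur; no ring) in place of a group of 3 heavy atoms (1 carbon, 1 nitrogen, 1 sulfur; no ring), on a saturated chain carbon, four bonds along the chain from an amide-type nitrogen. The surroundings are not the same, though: in the earlier pair the change sits six bonds along the chain from a sulfonamide nitrogen, here four bonds along the chain from an amide-type nitrogen.

A rise is expected because a number 16.5 percentage points higher from compound 1 to compound 2 (beyond the scatter) was upward, but a smaller one, since the place differs. The step is estimated as a number 7.8 percentage points higher from compound 3 to compound 4 (within the scatter). Compound 4 is expected to give 63%, between 46% and 78%.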

Compound 4, a percentage reported as inhibition, at one concentration (the size of the read-out at that concentration, not a potency): 50.3%
Compound 4: the middle estimate sits 12.7 percentage points above what was measured, and the stated range covers the measured number.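

On the core of compound 3, adding one more chain carbon, four bonds along the chain from an amide-type nitrogen, gave a number 4.9 percentage points lower from compound 3 to compound 4 (within the scatter) in this assay, so this step shows no clear change. The same change therefore did not carry over from one core to the other with the same effect: the same change on two cores in this assay, a number 16.5 percentage points higher (beyond the scatter) from compound 1 to compound 2 and a number 4.9 percentage points lower (within the scatter) from compound 3 to compound 4, 21.4 percentage points apart, beyond the scatter of two such steps

Among the compounds shown here, this shows that the rise seen with the sulfonamide pair cannot simply be assumed on the amide-linked core, but it does not show why the two steps differ, since the pairs differ both in the linking group and in where along the chain the change sits, and only two pairs, each read at one concentration, are available.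

The compounds shown leave open whether a longer chain on the amide-linked core would bring a clear rise or fall. They also leave open whether an amine in place of the group carried on the chain would keep any of the inhibition.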